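The source may hold more compounds than are shown below. What is called first, only, known or untested is meant among the compounds shown, and "the series" means these compounds.

Of the compounds shown here, two have been tested so far. Compound 1, `CCN(c1ccc(C#N)c(Cl)c1)c1cc(-c2ccoc2)ccc1C`, gives 4010 nM in a functional assay on VCaP cells (Homo sapiens) for antiproliferative activity, read by CCK-8 assay, with a stated time of 6 days; on this read-out higher numbers stand for weaker inhibition and lower numbers for stronger inhibition. Compound 2, `CCN(c1ccc(C#N)c(Cl)c1)c1cc(-c2cnc3ccccc3c2)ccc1C`, gives 25300 nM in the same assay. On these two numbers compound 1 stands lowest, and the gap to compound 2 lies beyond the usual scatter, so compound 1 is the stronger inhibitor of the pair.

Compound 3, `CCN(c1ccc(C#N)c(Cl)c1)c1cc(-n2ccnc2)ccc1C`, has not yet been measured. It differs from compound 1 in one place: 1H-imidazol-1-yl in place of furan-3-yl on an aromatic carbon. Both the group that leaves and the group that enters are five-membered aromatic rings of the same size, so the overall shape of compound 3 stays close to that of compound 1.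

Among the compounds with values here, no measured pair differing in a single place is available to calibrate this kind of swap. The expected step is a 1.7-fold higher number from compound 1 to compound 3 (0.24 log units; within the scatter), a modest weakening not far beyond the scatter. The estimate for compound 3 is therefore 7000 nM, with a range from 1800 nM to 28000 nM.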

Compound 3, half-maximal inhibitory concentration: > 30000 nM
Compound 3 was reported as a limit; the forecaster's own chance of this, stated with the estimate: 15%; middle value at least 4.2-fold (0.63 log units) from the limit.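

In this assay, placing 1H-imidazol-1-yl where furan-3-yl stood gives an at least 7.4-fold higher number from compound 1 to compound 3 (0.87 log units; beyond the scatter), so this place on the ring does not treat all five-membered aromatic rings alike. Both rings have the same count of heavy atoms, which shows that matching ring size alone does not preserve activity here. Compound 3 gives > 30000 nM, which is a limit of the assay and not a number, so the full size of the step stays unknown: the limit of > 30000 nM in this assay, at which 1 of the 3 values shown sits.

The compounds shown cannot separate the possible sources of this loss, such as the exchange of one oxygen for two nitrogens or the different way the new ring is attached. On these data alone, how a thiophene ring, with sulfur in place of the furan oxygen, or a simple amine would behave at this place also remains open.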